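Amide-to-sulfonamide swap on the shared core

The source may hold more compounds than are shown below. What is called first, only, known or untested is meant among the compounds shown, and "the series" means these compounds.

Measured compounds:
compound 1 `CN(C(=O)C(C)(C)C)c1ccc2[nH]c(-c3n[nH]c4ccccc34)cc2n1` — in a functional assay on HCT-116 cells (Homo sapiens) for antiproliferative activity, read by MTT assay, with a stated time of 72 h (a lower number here means a stronger inhibitor, a higher number a weaker inhibitor), compound 1 gives 18000 nM
compound 2 `CN(C(=O)c1ccc(Cl)cc1)c1ccc2[nH]c(-c3n[nH]c4ccccc34)cc2n1` — compound 2 gives 3000 nM
compound 3 `COc1cccc(C(=O)N(C)c2ccc3[nH]c(-c4n[nH]c5ccccc45)cc3n2)c1` — compound 3 gives 14200 nM

Compound 1 gives the highest number of the three. Compound 3 stands nearest, the step of a 1.3-fold lower number from compound 1 to compound 3 (0.10 log units; within the scatter) lying within the scatter, while compound 2 stands furthest, with a 6.0-fold lower number from compound 1 to compound 2 (0.78 log units; beyond the scatter). Between the two aromatic replacements, a 4.7-fold higher number from compound 2 to compound 3 (0.68 log units; beyond the scatter).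

Compound 4 `CN(c1ccc2[nH]c(-c3n[nH]c4ccccc34)cc2n1)S(=O)(=O)c1ccccc1` differs from compound 1 in one place: phenylsulfonyl in place of (tert-butyl)carbonyl on a nitrogen on an aromatic ring. The two measured steps from compound 1 both put an aromatic ring in place of tert-butyl on a carbonyl carbon, and they disagree: one modest lowering, one no change beyond the scatter. Within the data shown here, no measured step replaces the carbonyl itself with a sulfonyl, so the new group has no direct precedent here. The aromatic ring entering is shared with compounds 2 and 3, which suggests at most a modest lowering. The step from compound 1 to compound 4 is expected to be a 2.3-fold lower number from compound 1 to compound 4 (0.35 log units; beyond the scatter). Compound 4 is estimated at 8000 nM, with a range of 2000 nM to 25000 nM.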

Compound 4, half-maximal inhibitory concentration: 6740 nM
Beside the measured number, compound 4's estimate is 1.2-fold (0.07 log units) above it; low and high end bracket the measured number.
By their numbers in this assay, from the lowest: compound 2; then compound 4; then compounds 3 and 1 (each within the scatter of the next).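

On the nitrogen on an aromatic ring, a sulfonyl link can replace the carbonyl with activity retained in this assay: phenylsulfonyl gives a 2.7-fold lower number from compound 1 to compound 4 (0.43 log units; beyond the scatter) and a 2.1-fold lower number from compound 3 to compound 4 (0.32 log units; beyond the scatter). It does not reach the (4-chlorophenyl)carbonyl group, with a 2.2-fold higher number from compound 2 to compound 4 (0.35 log units; beyond the scatter), so compound 2 keeps the lowest number of the four, and in each of these steps the link and the group attached to it change together. No measurement available here explains these differences.

Among these compounds, the contribution of the sulfonyl alone remains open, since no pair keeps the same aromatic ring while changing only the link; phenylcarbonyl and 4-chlorophenylsulfonyl would each supply such a pair. As far as these compounds go, whether the sulfonyl needs an aromatic ring at all also remains open, and methylsulfonyl or tert-butylsulfonyl would address that.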